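Aryloxy swaps on a shared core, all at the limit

The compounds below may be only part of what the source reports. "The series", "measured", "known", "first", "only" and "open" are said of these compounds alone.

Compound 1 `CC(C)[C@H](NC(=O)COc1cccc2ccccc12)C(=O)N[C@@H](CC(=O)O)C(=O)COc1cccc2ccccc12`: in a functional assay on Jurkat cells (Homo sapiens) (on this read-out higher numbers stand for weaker inhibition and lower numbers for stronger inhibition), compound 1 gives > 100000 nM, a limit of the assay.
Compound 2 `CC(C)[C@H](NC(=O)COc1cccc2ccccc12)C(=O)N[C@@H](CC(=O)O)C(=O)COc1ccc(C(F)(F)F)cc1`: compound 2 gives > 100000 nM, again a limit.
Compound 3 `CC(C)[C@H](NC(=O)COc1cccc2ccccc12)C(=O)N[C@@H](CC(=O)O)C(=O)COc1cc(F)ccc1F`: compound 3 gives > 100000 nM, also a limit.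

Compound 1 therefore stands only at a limit in this assay, and the two other values shown are limits too (the limit of > 100000 nM in this assay, at which 3 of the 3 values shown sit). The step from compound 1 to compound 2 is a step that the two limits leave unreadable from compound 1 to compound 2, the step from compound 1 to compound 3 is a step that the two limits leave unreadable from compound 1 to compound 3, and the step from compound 2 to compound 3 is a step that the two limits leave unreadable from compound 2 to compound 3; none of these can be sized, since both ends sit at the limit.

Compound 4 `CC(C)[C@H](NC(=O)COc1cccc2ccccc12)C(=O)N[C@@H](CC(=O)O)C(=O)COc1ccc(F)c(F)c1F` differs from compound 1 by 2,3,4-trifluorophenyl in place of naphthalen-1-yl on an oxygen on a saturated carbon. Among the measured compounds shown here, the steps that bear on it, from compound 1 to compound 2 and from compound 1 to compound 3, are both unreadable in size, so no direction beyond the scatter can be expected in this assay; the closest analogue, compound 3, is itself at the limit. Compound 4 is expected to give 200000 nM, most likely again reported only as a limit, within 100000 nM to 1000000 nM. The expected step from compound 1 to compound 4 is a step that the limit leaves unreadable from compound 1 to compound 4.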

Compound 4, half-maximal inhibitory concentration: 35800 nM
Compound 4: middle estimate off by 5.6-fold (0.75 log units), on the high side; the whole stated range lies above it.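

In this assay, the aryl group on this oxygen can move the read-out after all: 2,3,4-trifluorophenyl in place of naphthalen-1-yl gives an at least 2.7-fold lower number from compound 1 to compound 4 (0.44 log units; beyond the scatter), and the swaps from the other two aryl groups give an at least 2.7-fold lower number from compound 3 to compound 4 (0.44 log units; beyond the scatter) and an at least 2.7-fold lower number from compound 2 to compound 4 (0.44 log units; beyond the scatter). Fluorine on a phenyl ring is not enough by itself, as compound 3, with its 2,5-difluorophenyl group, gives > 100000 nM, which is a limit. These three steps are minimum sizes, and the steps among compound 1, compound 2 and compound 3 cannot be read at all, because those three compounds sit at a limit: the limit of > 100000 nM in this assay, at which 3 of the 4 values shown sit.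

Compound 3 and compound 4 differ in both the number and the places of their fluorines, so the compounds shown cannot separate these two changes. Where a plain phenyl or a pentafluorophenyl group on this oxygen would fall remains open, as does whether the 2,3,4-trifluorophenyl group would have the same effect with something other than the naphthalen-1-yl group at the far end of the shared core.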